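The source may hold more compounds than are shown below. What is called first, only, known or untested is meant among the compounds shown, and "the series" means these compounds.

Measured so far:
compound 1 `CCC(C)O[C@@H]1C[C@@H]2[C@H]([C@]1(N)C(=O)O)[C@@]2(F)C(=O)O` — 6.68 nM
compound 2 `N[C@]1(C(=O)O)[C@H]2[C@@H](C[C@H]1OCCCc1ccccc1)[C@]2(F)C(=O)O` — 9.83 nM
compound 3 `N[C@]1(C(=O)O)[C@H]2[C@@H](C[C@H]1OCc1ccccc1Cl)[C@]2(F)C(=O)O` — 4.99 nM

In an assay on CHO cells for binding affinity to metabotropic glutamate receptor 2 (Rattus norvegicus) (a lower number here means a stronger inhibitor, a higher number a weaker inhibitor), compound 3 gives the lowest number of the three, yet compound 1 and compound 2 both stand within the scatter of it. Within the data shown here, the only measured step, a 2.0-fold lower number from compound 2 to compound 3 (0.29 log units; within the scatter), shows that exchanging the group on the saturated chain carbon bound to an oxygen changes little. Compound 4 `N#Cc1cccc(CO[C@@H]2C[C@@H]3[C@H]([C@]2(N)C(=O)O)[C@@]3(F)C(=O)O)c1` carries the change (3-cyanophenyl in place of 2-chlorophenyl on a saturated chain carbon bound to an oxygen on a saturated carbon). Among the measured compounds shown here, no measured step swaps one substituted phenyl for another, so that single step bears on it only indirectly, and the expected step is a 1.3-fold higher number from compound 3 to compound 4 (0.11 log units; within the scatter), none beyond the scatter. Compound 4 is estimated at 6.5 nM with a range from 2.5 nM to 17 nM.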

Compound 4, inhibition constant: 2.94 nM
The estimate for compound 4 lay 2.2-fold (0.34 log units) above the measured number; low and high end bracket the measured number.
By their numbers in this assay, from the lowest: compounds 4, 3, 1 and 2 (each within the scatter of the next, the first and the last beyond it).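

In this assay, placing 3-cyanophenyl where compound 3 carries 2-chlorophenyl gives a step that stays small (a 1.7-fold lower number from compound 3 to compound 4 (0.23 log units; within the scatter)), so on a saturated chain carbon bound to an oxygen on a saturated carbon, a nitrile on the phenyl ring holds the number as well as a chlorine does. The same position also yields its first step beyond the scatter, though a modest one (a 3.3-fold lower number from compound 2 to compound 4 (0.52 log units; beyond the scatter)). No measurement here explains either step. The compounds shown leave open whether an amine or a carboxylic acid on that phenyl ring would hold the number as well.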